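A few compounds are considered here, and "the series" means these few. Any claim that something is new, unique, unknown or untested is made for them only; others in the source may bear on it.

Among the compounds with values here, compound 1 `CC1(C)C=C(n2ccccc2=O)c2ccccc2O1` gives 5.43 in a functional assay (aorta) with Rattus norvegicus as the target (on this read-out higher numbers stand for higher potency (the scale is a negative logarithm) and lower numbers for lower potency), and stands higher than the only other measured compound, compound 2 `CC1(C)C=C(n2ccccc2=O)c2cc(OC(=O)Nc3ccc(C(F)(F)F)cc3)ccc2O1`, which gives 5.1 in this assay, a gap beyond the usual scatter. Within the data shown here, compound 2 carries a large substituent on the aromatic carbon of the shared core where compound 1 has hydrogen, so the one comparison available points slightly downward when that position is occupied.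

Compound 3 `CC1(C)C=C(n2ccccc2=O)c2cc(C#N)ccc2O1` is not yet measured. It differs from compound 1 by a single change: cyano in place of hydrogen on an aromatic carbon. Among the measured compounds shown here, with no measured step of this exact kind to lean on, the step from compound 1 to compound 3 is expected to be small, most likely within the scatter, perhaps leaning a little lower as the value of compound 2 5.1 suggests, giving an expected step of a number 0.13 log units lower from compound 1 to compound 3 (within the scatter). Compound 3 is therefore estimated at 5.3, within a range from 4.8 to 5.8.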

Compound 3, logarithm of the reciprocal of the active concentration, log(1/C): 7.67
Beside the measured number, compound 3's estimate is 2.37 log units below it; the whole stated range lies below it.
By their numbers in this assay, from the lowest: compound 2; then compound 1; then compound 3.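

Cyano in place of hydrogen on this aromatic carbon brings a number 2.24 log units higher from compound 1 to compound 3 (beyond the scatter) in this assay, a large rise. Compound 2, with its large substituent on the same carbon, gives 5.1, so compound 3 goes against the slight downward lean that compound 2 alone had suggested. Occupying this carbon therefore does not lower the number as such, and the outcome differs with the group that enters. Nothing measured here explains the size of this step.

The compounds shown leave open whether an amine, a carboxylic acid or a methoxy group on this carbon would fall near compound 1 or near compound 3. They also leave open whether cyano would bring a similar rise on any other aromatic carbon of the shared core.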